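Inverting one ring stereocentre of compound 1

The compounds below may be only part of what the source reports. "The series", "measured", "known", "first", "only" and "open" are said of these compounds alone.

Compound 1 `CCCCCCCn1cc(COC[C@@H]2OC[C@H](N)[C@@H]2O)nn1` gives > 128000 nM as a limit
Compound 2 `CCCCCCCCCCCCCCCCn1cc(COC[C@@H]2OC[C@H](N)[C@@H]2O)nn1` gives 3300 nM as measured
Compound 3 `CCCCCCCCCCCCCCCCCCn1cc(COC[C@@H]2OC[C@H](N)[C@@H]2O)nn1` gives 7580 nM as measured

In a functional assay on MCF7 cells (Homo sapiens) for antiproliferative activity, read by MTT assay, with a stated time of 48 h (a higher number here means a weaker inhibitor, a lower number a stronger inhibitor), compound 1 reads > 128000 nM and that reading is a limit, not a number. Compound 1 sits at the limit of > 128000 nM in this assay, at which 1 of the 3 values shown sits, and has no measured value of its own.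

The change to compound 4 `CCCCCCCn1cc(COC[C@@H]2OC[C@H](N)[C@H]2O)nn1` reads the two compounds have the same atoms and bonds and differ only in configuration as drawn: 1 of 3 stereo elements differ; a stereocentre at a saturated ring carbon is drawn S in compound 1 and R in compound 4 and concerns a stereocentre at a saturated ring carbon, drawn S in compound 1 and R in compound 4. Within the data shown here, no measured step alters a stereocentre, so none speaks to this change directly. The measured steps all alter the chain, with an at least 38-fold lower number from compound 1 to compound 2 (1.58 log units; beyond the scatter) and an at least 16-fold lower number from compound 1 to compound 3 (1.22 log units; beyond the scatter) both large and a 2.3-fold higher number from compound 2 to compound 3 (0.36 log units; beyond the scatter) modest. Compound 4 keeps the chain unchanged, so the expectation rests on compound 1 and its limit of > 128000 nM alone.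

The expected outcome is a number no higher from compound 1 to compound 4 (the limit leaves the size open) in this assay with no step beyond the scatter expected. Compound 4 is estimated at 128000 nM with an expected range from 50000 nM to 260000 nM and a report as a limit is the likeliest result.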

Compound 4, half-maximal inhibitory concentration: > 128000 nM
Compound 4: only a limit was reported; the forecaster's own chance of this, stated with the estimate: 80%; the middle value lies on the limit itself.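

Compound 1 and compound 4 both read as limits in this assay, so no step between them can be read: the limit of > 128000 nM in this assay, at which 2 of the 4 values shown sit.

The compounds shown leave open whether inverting this ring stereocentre would change the reading on the longer chains of compound 2 and compound 3, which give measured values.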